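A few compounds are considered here, and "the series" means these few. Any claim that something is new, unique, unknown or untested is made for them only; others in the source may bear on it.

Measured so far:
- compound 1 `O=C(Nc1ccc(-n2cc(CCO[C@H]3O[C@@H](CO)[C@H](O)[C@@H]3O)nn2)cc1)Nc1ccccc1C(F)(F)F` in an assay on isolated protein for inhibition of ATP-dependent RNA helicase DDX3X (Homo sapiens), read by FRET, with stated times of 30 s and 40 min; on this read-out lower numbers stand for stronger inhibition and higher numbers for weaker inhibition: "not active" (no number reported)
- compound 2 `Cc1ccccc1NC(=O)Nc1ccc(-n2cc(CCCN(C)C)nn2)cc1` in this assay: 2900 nM

Compound 1 stands on no number at all: in this assay compound 1 is reported as "not active" (no number reported), so there is no value from which a step can be counted. Compound 2, which shares the urea and the triazole-bearing core but carries a different chain and a different ring substituent, gives 2900 nM in this assay; no single change links it to compound 1, so its value only shows that this kind of core can register in the assay.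

Compound 3 `CCOC(=O)CCc1cn(-c2ccc(NC(=O)Nc3ccccc3C(F)(F)F)cc2)nn1` is compound 1 with one change: ethoxycarbonyl in place of (3,4-dihydroxy-5-(hydroxymethyl)oxolan-2-yl)oxy on a saturated chain carbon, two bonds along the chain from an aromatic carbon. Among the compounds with values here, since compound 1 has no number, no direction of the step can be measured; the expectation is that compound 3 either stays without a number or appears as a weak inhibitor in the same region as compound 2. On this basis compound 3 is expected to give about 6000 nM, with a range from 1500 nM to 30000 nM, and a real chance that the assay again reports no number.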

Compound 3, half-maximal inhibitory concentration: 2020 nM
Beside the measured number, compound 3's estimate is 3.0-fold (0.47 log units) above it; measured number inside the range.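

No step can be read from compound 1 to compound 3: in this assay compound 3 gives 2020 nM while compound 1 is reported as "not active" (no number reported) and so offers no number to count from. These two compounds leave open how far apart they really lie and which part of the exchanged group matters. No supporting evidence bears on this result.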